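The source may hold more compounds than are shown below. What is called first, only, known or untested is meant among the compounds shown, and "the series" means these compounds.

Measured so far:
compound 1 `O=C(NCc1ccccc1)c1csc(-c2c[nH]c3ccccc23)n1` — 9510 nM
compound 2 `COc1ccc2[nH]cc(-c3nc(C(=O)Nc4cc(OC)c(OC)c(OC)c4)cs3)c2c1` — 29600 nM
compound 3 `COc1cc(NC(=O)c2csc(-c3c[nH]c4ccc(Br)cc34)n2)cc(OC)c1OC` — 55800 nM

Of the compounds shown here, three sharing one core have been tested in a functional assay on HeLa cells (Homo sapiens) for cytotoxicity, read by MTT assay, with a stated time of 48 h, in the absence of a further agent; a higher number here means a weaker inhibitor, a lower number a stronger inhibitor. Compound 1 gives 9510 nM, the lowest of the three numbers, so it is the strongest inhibitor here. Compound 2 gives 29600 nM and compound 3 gives 55800 nM, both beyond the scatter above compound 1. Going by the values given here, the only single-point step among them, a 1.9-fold higher number from compound 2 to compound 3 (0.28 log units; within the scatter), falls within the scatter. Compound 4 `Cc1ccc(NC(=O)c2csc(-c3c[nH]c4ccccc34)n2)cc1` has not yet been tested. It differs from compound 1 by 4-methylphenyl in place of benzyl on an amide-type nitrogen. Among the compounds with values here, no measured step covers this exact change: compounds 2 and 3 also carry a ring directly on the amide-type nitrogen rather than through a benzyl link, but each of them differs from compound 1 in further places as well, so their higher numbers cannot be traced to the amide substituent alone. The change from compound 1 to compound 4 is therefore expected to produce only a modest shift, a 1.5-fold higher number from compound 1 to compound 4 (0.17 log units; within the scatter), with no firm direction. Compound 4 is estimated at 14000 nM, within a range from 5000 nM to 40000 nM.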

Compound 4, half-maximal inhibitory concentration: > 100000 nM
Compound 4 ended at the assay's limit; the forecaster's own chance of this, stated with the estimate: 10%; middle value at least 7.1-fold (0.85 log units) from the limit.
By their numbers in this assay, from the lowest: compound 1; then compounds 2 and 3 (each within the scatter of the next). At a limit, above all of these: compound 4.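

In this assay compound 4 gives > 100000 nM, which is a limit of the assay and not a number: the limit of > 100000 nM in this assay, at which 1 of the 4 values shown sits.

Putting 4-methylphenyl in place of benzyl on the amide-type nitrogen gives an at least 10-fold higher number from compound 1 to compound 4 (1.02 log units; beyond the scatter). The two compounds have the same atoms, joined differently, so at this position the way those atoms are arranged matters a great deal in this assay, not merely which atoms are present.

The compounds shown leave open whether the large step comes from losing the carbon link between the ring and the nitrogen or from gaining the methyl on the ring. A plain phenyl and a 4-methylbenzyl on the same nitrogen would separate these two parts of the change, and a longer chain such as 2-phenylethyl would show how the number responds as the link grows.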